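Swapping a Sulfonamide Arm for a Methoxyethyl Ester

The compounds below may be only part of what the source reports. "The series", "measured", "known", "first", "only" and "open" are said of these compounds alone.

Of the compounds shown here, three have been measured in an assay on COS-7 cells for inhibition of patatin-like phospholipase domain-containing protein 2 (Mus musculus), tested at 200 uM; on this read-out higher numbers stand for more inhibition at the one concentration tested (going by the name of the read-out) and lower numbers for less inhibition. Compound 1 `CCOC(=O)c1cccc(-c2ccc(OC)cc2)c1` gives 77%, compound 2 `CCOC(=O)c1cccc(-c2cccs2)c1` gives 55%, and compound 3 `CCNS(=O)(=O)c1cccc(-c2ccc(OCC)cc2)c1` gives 46%. Compound 3 stands lowest of the three numbers: its gap to compound 2 lies within the scatter of this assay, while its gap to compound 1 lies beyond it.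

Compound 4 `CCOc1ccc(-c2cccc(C(=O)OCCOC)c2)cc1` has not yet been measured. Compared with compound 3, it shows ((2-methoxyethoxy)carbonyl in place of ethylsulfamoyl on an aromatic carbon).

Among the compounds with values here, no step between measured compounds is available for this exact change, so the expectation rests on the values themselves. Because compound 1 gives 77% with a related carbonyl arm on the shared core, compound 4 is expected to sit well above compound 3. The step from compound 3 to compound 4 is estimated at a number 22 percentage points higher from compound 3 to compound 4 (beyond the scatter) in this assay, upward and beyond the scatter. Compound 4 is therefore expected to give about 68%, within a range from 50% to 85%.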

Compound 4, a percentage reported as inhibition, at one concentration (the size of the read-out at that concentration, not a potency): 89%
Estimate against measurement, compound 4: 21 percentage points below; measured number outside the range, above it.
By their numbers in this assay, from the lowest: compounds 3 and 2 (each within the scatter of the next); then compound 1; then compound 4.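

Changing only the group on this aromatic carbon, with the rest of the molecule held the same, gives a number 43 percentage points higher from compound 3 to compound 4 (beyond the scatter) in this assay, so this position clearly matters for the read-out. The earlier compounds shown here could not show this, since no two of them differed in just one place. The swap alters several things at once, removing the sulfur, the nitrogen and its hydrogen-bond donor while adding a carbonyl and a longer chain, and no measurement here explains the gain.

From the compounds shown here alone, it remains open whether the gain comes from the carbonyl link or from the methoxyethyl chain beyond it. A carboxylic acid, an amide or a plain butyl ester at this position would help separate those two parts.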